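Replacing piperazin-1-yl in compound 3

The compounds below may be only part of what the source reports. "The series", "measured", "known", "first", "only" and "open" are said of these compounds alone.

compound 1 `CC(C)c1cc(-n2nncc2-c2ccc(CN3CCN(c4ccccc4)CC3)cc2)c(O)cc1O` – 520 nM
compound 2 `CC(C)c1cc(-n2nncc2-c2ccc(CN3CCCC(O)C3)cc2)c(O)cc1O` – 45 nM
compound 3 `CCNC(=O)c1nnn(-c2cc(C(C)C)c(O)cc2O)c1-c1ccc(CN2CCNCC2)cc1` – 250 nM

All three values come from a functional assay on NCI-H460 cells (Homo sapiens) for inhibition, read by sulforhodamine B assay, with a stated time of 72 h; a lower number here means a stronger inhibitor, a higher number a weaker inhibitor. Compound 3 holds the middle position, and its gaps to both other compounds lie beyond the scatter. Compound 1 sits above it, and compound 2 sits below it.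

Compound 4 `CCNC(=O)c1nnn(-c2cc(C(C)C)c(O)cc2O)c1-c1ccc(CNC2CCN(C)CC2)cc1` is still unmeasured. The change from compound 3 is (1-methylpiperidin-4-yl)amino in place of piperazin-1-yl on a saturated chain carbon bound to an aromatic carbon, with (1-methylpiperidin-4-yl)amino in place of piperazin-1-yl on a saturated chain carbon bound to an aromatic carbon. Among the compounds with values here, no measured pair isolates this kind of change, so the expectation stays close to compound 3 at 250 nM as the nearest measured structure. A small shift toward a lower number is expected in this assay, not beyond the scatter. The estimated change is a 1.5-fold lower number from compound 3 to compound 4 (0.17 log units; within the scatter), and it remains uncertain in direction. Compound 4 is expected at 170 nM, with an estimated range of 60 nM to 480 nM.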

Compound 4, half-maximal inhibitory concentration: > 1000 nM
Compound 4: only a limit was reported; the forecaster's own chance of this, stated with the estimate: 2%; at least 5.8-fold (0.76 log units) between middle value and limit.
By their numbers in this assay, from the lowest: compound 2; then compound 3; then compound 1. At a limit, above all of these: compound 4.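

In this assay compound 4 carries only a limit, > 1000 nM, and not a number. Within the data shown here, the exchange of piperazin-1-yl for (1-methylpiperidin-4-yl)amino on a saturated chain carbon bound to an aromatic carbon gives an at least 4.0-fold higher number from compound 3 to compound 4 (0.60 log units; beyond the scatter), the only step that isolates a change at this place, and it shows that the read-out here depends on the group carried there. The size of this step is a lower bound and its upper end stays unknown: the limit of > 1000 nM in this assay, at which 1 of the 4 values shown sits.

The compounds shown do not separate the contribution of the methyl group from that of the amino link within (1-methylpiperidin-4-yl)amino. Piperidin-4-ylamino and 4-methylpiperazin-1-yl at the same place would each test one of these features alone.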